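This account rests on a few compounds, and the source may have more. Where it says the series, first, only, none or still open, it means among the compounds named here.

Of the compounds shown here, two have been read so far in a functional assay on HCT-116 cells (Homo sapiens) for inhibition, read by CCK-8 assay, with a stated time of 48 h; on this read-out higher numbers stand for weaker inhibition and lower numbers for stronger inhibition. Compound 1 (`COc1cc(-c2ccnc3cc(-c4ccc(C)cc4)nn23)cc(OC)c1OC`) stands lowest of the two at 48 nM, while compound 2 (`Cn1ccc2cc(-c3cc4nccc(-c5ccc(F)cc5)n4n3)ccc21`) reads far higher at 2160 nM, a gap beyond the scatter. These two compounds differ in more than one place, so their gap cannot be assigned to any single group. Compound 3 (`COc1cc(-c2ccnc3cc(-c4ccc5cc[nH]c5c4)nn23)cc(OC)c1OC`) keeps the rest of compound 1 and changes one group, with 1H-indol-6-yl in place of 4-methylphenyl on an aromatic carbon. Both groups contain a six-membered aromatic ring of carbon only, and the entering group adds a five-membered aromatic ring with 1 hetero atom. Among the compounds with values here, no measured pair shows this change alone, so the expectation starts from compound 1 at 48 nM and carries real uncertainty. Only a small step is expected in this assay, leaning towards stronger inhibition but not beyond the scatter. The estimate amounts to a 1.6-fold lower number from compound 1 to compound 3 (0.20 log units; within the scatter). Compound 3 is expected at 30 nM, with an estimated range of 8 nM to 120 nM.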

Compound 3, half-maximal inhibitory concentration: 187 nM
Beside the measured number, compound 3's estimate is 6.2-fold (0.79 log units) below it; measured number outside the range, above it.
By their numbers in this assay, from the lowest: compound 1; then compound 3; then compound 2.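

In this assay, within the data shown here, this is the first comparison that changes one place only, and it shows that an aromatic carbon of the five-membered aromatic ring with 2 nitrogen is sensitive to the group it carries: 1H-indol-6-yl in place of 4-methylphenyl gives a 3.9-fold higher number from compound 1 to compound 3 (0.59 log units; beyond the scatter) and so goes with weaker inhibition. Of the two groups compared at this position, 4-methylphenyl therefore gives the stronger inhibition on the rest of compound 1. The step covers the change as a whole, so it cannot separate the entering five-membered aromatic ring from the hydrogen-bond donor that comes with it, and nothing at hand explains the rise in the number.

The compounds shown leave open how this position would respond to a group without a six-membered aromatic ring, such as morpholine or a short alkyl chain, and whether a phenyl ring with methoxy or chlorine in place of the methyl would read nearer compound 1 or compound 3. They also do not tell whether the same exchange would give a step of similar size on the rest of compound 2.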